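The source may hold more compounds than are shown below. What is called first, only, known or untested is meant among the compounds shown, and "the series" means these compounds.

Among the compounds with values here, compound 1 `COc1cccc(C#Cc2csc(C)n2)c1` is one of two compounds measured in a functional assay on CHO cells for agonist activity at metabotropic glutamate receptor 5 (Homo sapiens), read by inositol phosphate accumulation; a lower number here means a stronger inhibitor, a higher number a weaker inhibitor. In this assay compound 1 gives 49 nM, the higher of the two numbers recorded. Its only companion, compound 2 `Cc1nc(C#Cc2cc(F)cc(F)c2)cs1`, gives 25.3 nM in this assay; the gap between the two numbers lies within the scatter of repeated measurements, so the two compounds cannot be separated on this evidence.

Compound 3 `Cc1nc(C#Cc2cccc(C(N)=O)c2)cs1` has not yet been measured. It differs from compound 1 in a single place: carbamoyl in place of methoxy on an aromatic carbon. Within the data shown here, no pair of measured compounds shows this exchange, so there is no directly comparable step to lean on.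

The expectation for compound 3 therefore rests on compound 1 alone, whose number of 49 nM is the starting point. A somewhat higher number is expected for compound 3, a step of a 2.4-fold higher number from compound 1 to compound 3 (0.39 log units; beyond the scatter) in this assay, although a result inside the scatter would not be surprising. Compound 3 is estimated to give 120 nM, with a likely range from 40 nM to 400 nM.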

Compound 3, half-maximal inhibitory concentration: 1000 nM
Compound 3: middle estimate off by 8.3-fold (0.92 log units), on the low side, and the stated range ends below it.
By their numbers in this assay, from the lowest: compounds 2 and 1 (each within the scatter of the next); then compound 3.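

In this assay, putting carbamoyl in place of methoxy on this aromatic carbon gives a 20-fold higher number from compound 1 to compound 3 (1.31 log units; beyond the scatter), so compound 3 is the weaker inhibitor by a clear margin and this position on the six-membered aromatic ring does not tolerate every group equally. The two groups differ in more than one counted feature: methoxy has 2 heavy atoms and 0 hydrogen-bond donors, whereas carbamoyl has 3 heavy atoms, 1 hydrogen-bond donor and 1 double bond outside aromatic rings, and this single exchange cannot show which of these differences matters. Nothing available here gives a measured explanation for the drop in activity.

The compounds shown leave open whether the drop is peculiar to carbamoyl or would also appear with other groups on the same carbon, such as an amine, a carboxylic acid or a methyl ester. Within the data shown here, with only one pair showing this exchange, it is also unknown whether carbamoyl would have a similar effect at another place on the ring or on a ring that also carries fluorine atoms.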